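Opening a piperazine ring on a pyridine-linked isoindolinone

A few compounds are considered here, and "the series" means these few. Any claim that something is new, unique, unknown or untested is made for them only; others in the source may bear on it.

Three compounds with measured numbers frame this account. Compound 1 `CC1(C)c2cc(Cl)ccc2C(=O)N1c1cncc(N2CCN(S(C)(=O)=O)CC2)c1` carries a methylsulfonyl on the piperazine nitrogen and gives 2 nM in an assay on cells for inhibition of cytochrome P450 11B2, mitochondrial (Homo sapiens), read by HTRF; a lower number here means a stronger inhibitor, a higher number a weaker inhibitor. Compound 2 `CC(=O)N1CCN(c2cncc(N3C(=O)c4ccc(Cl)cc4C3(C)C)c2)CC1` is the acetyl counterpart of compound 1; in this assay compound 2 gives 9 nM. Going by the values given here, compound 3 `Cc1cc(Cl)ccc1C(=O)Nc1cccnc1`, built on a simpler amide core, gives 277 nM; its value and that of compound 2 differ widely, though no single-place step links them. Compound 2 therefore stands second highest of the three numbers, closer to compound 1 than to compound 3.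

Among the compounds with values here, the one directly relevant step is a 4.5-fold higher number from compound 1 to compound 2 (0.65 log units; beyond the scatter), which shows that swapping methylsulfonyl for acetyl on that ring nitrogen shifts the number modestly. Compound 4 `C[C@@H](NS(C)(=O)=O)c1cncc(N2C(=O)c3ccc(Cl)cc3C2(C)C)c1` departs from compound 2 by a group of 7 heavy atoms (3 carbon, 1 nitrogen, 2 oxygen, 1 sulfur; no ring) in place of a group of 9 heavy atoms (6 carbon, 2 nitrogen, 1 oxygen; one six-membered non-aromatic ring with 2 hetero atoms), on an aromatic carbon. Within the data shown here, the entering group brings a methylsulfonyl back, now on a nitrogen with a hydrogen, while the piperazine ring is gone; no measured pair shows what removing that ring does.

Because the return of the methylsulfonyl recalls the value of compound 1 2 nM, compound 4 is expected to sit near or somewhat below compound 2. The estimated step is a 1.5-fold lower number from compound 2 to compound 4 (0.18 log units; within the scatter), likely within the scatter. The estimate for compound 4 is 6 nM, with a range from 1.5 nM to 25 nM.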

Compound 4, half-maximal inhibitory concentration: 8 nM
The estimate for compound 4 lay 1.3-fold (0.12 log units) below the measured number; measured number inside the range.
By their numbers in this assay, from the lowest: compound 1; then compounds 4 and 2 (each within the scatter of the next); then compound 3.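

The step of a 1.1-fold lower number from compound 2 to compound 4 (0.05 log units; within the scatter) in this assay shows that the 4-acetylpiperazin-1-yl group is not needed for a low number at this place, on an aromatic carbon two atoms from the ring nitrogen. Going by these compounds alone, the earlier compounds all left this unanswered, since the only step among them changed the group on the piperazine nitrogen and kept the ring itself. Here a group with no ring, a hydrogen-bond donor and a defined stereocentre reads the same within the scatter, so this position accepts two quite different groups, although nothing on hand explains why they read alike.

What remains open is how much of the number rests on the methylsulfonyl of the entering group and how much on its defined stereocentre, as neither is varied alone among the compounds shown. An acetyl on the same nitrogen, a free amine, a carboxylic acid or a longer chain at this place, or the mirror-image form of compound 4, would each separate those contributions.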